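Fluoro to methyl on the pendant phenyl ring

A few compounds are considered here, and "the series" means these few. Any claim that something is new, unique, unknown or untested is made for them only; others in the source may bear on it.

For the measured compounds named here, compound 2 `Cc1cc(-c2nnc3n2CCCCC3)c(C)n1-c1ccc(F)cc1` gives 121 nM in an assay on isolated protein for inhibition of 15-hydroxyprostaglandin dehydrogenase [NAD(+)] (Homo sapiens), read by fluorescence, with a stated time of 15 min (a lower number here means a stronger inhibitor, a higher number a weaker inhibitor), the highest of the two numbers measured so far; its only neighbour is compound 1 `Cc1cc(-c2nnc3n2CCCCC3)c(C)n1-c1ccc(Br)cc1`, which gives 48 nM. Going by the values given here, the one step available, a 2.5-fold higher number from compound 1 to compound 2 (0.40 log units; beyond the scatter), exchanges one halogen for another at the position in question. Compound 3 `Cc1ccc(-n2c(C)cc(-c3nnc4n3CCCCC4)c2C)cc1` differs from compound 2 by methyl in place of fluoro on an aromatic carbon. Among the compounds with values here, no measured step covers a methyl at this place, so the halogen step speaks only to the sensitivity of the position and gives no direction for a carbon substituent. The two measured values bracket a narrow window, and a methyl could land near either end of it. Compound 3 is therefore expected to give roughly 70 nM, with a range of 25 nM to 200 nM. The expected step of a 1.7-fold lower number from compound 2 to compound 3 (0.24 log units; within the scatter) is small and may not exceed the scatter.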

Compound 3, half-maximal inhibitory concentration: 34 nM
The estimate for compound 3 lay 2.1-fold (0.31 log units) above the measured number, and the stated range covers the measured number.
By their numbers in this assay, from the lowest: compounds 3 and 1 (each within the scatter of the next); then compound 2.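

With a 3.6-fold lower number from compound 2 to compound 3 (0.55 log units; beyond the scatter) in this assay, a carbon substituent is accepted at this place on the phenyl ring, so the earlier halogen step no longer stands alone as a guide to the position. Against the bromo group, methyl shows no separation, since a 1.4-fold lower number from compound 1 to compound 3 (0.15 log units; within the scatter) gives the two groups no order. Among the three groups, fluoro alone stands apart, with its steps to both others beyond the scatter, and no supporting evidence is available to account for this.

The compounds shown leave open whether an ethyl or longer chain, a methoxy group, an amine or a carboxylic acid would fit the same trend at this place. They also leave open whether the fluoro-to-methyl step carries over to a different core.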